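Methylsulfonyl for methylsulfanyl, two pairs compared

This account rests on a few compounds, and the source may have more. Where it says the series, first, only, none or still open, it means among the compounds named here.

Measured compounds:
Compound 1 `CSc1nnc(-c2cccc3ccccc23)n1C` in a functional assay on the whole organism for antagonist activity, with Mus musculus as the target (on this read-out lower numbers stand for an effect already at smaller amounts and higher numbers for an effect only at larger amounts of compound), gives > 200 mg/kg, which is a limit of the assay.
Compound 2 `Cn1c(-c2cccc3ccccc23)nnc1S(C)(=O)=O` gives > 200 mg/kg, also a limit.
Compound 3 `CSc1nc(-c2ccc(Cl)cc2)nn1C` gives > 200 mg/kg, again a limit.

Notes. In this assay none of the three measured compounds reaches a number; all sit at the limit of > 200 mg/kg in this assay, at which 3 of the 3 values shown sit. The change from compound 1 to compound 2 is methylsulfonyl in place of methylsulfanyl on an aromatic carbon, and the step it made is a step that the two limits leave unreadable from compound 1 to compound 2. How the core of compound 3 differs from the core of compound 1 is not broken down here.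

Compound 4 `Cn1nc(-c2ccc(Cl)cc2)nc1S(C)(=O)=O` is not yet measured. Its change from compound 3 is methylsulfonyl in place of methylsulfanyl on an aromatic carbon. The surroundings of the place read alike in both pairs except that in the pair of compound 1 and compound 2 the ring atom two ring bonds away bears a large group, while in the pair of compound 3 and compound 4 it bears a group of 7 heavy atoms; so the change is of the same kind, not the same.

The step from compound 3 to compound 4 is expected to be a step that the limit leaves unreadable from compound 3 to compound 4, resting on the fact that compound 1 gives > 200 mg/kg and compound 2 gives > 200 mg/kg for the same kind of change, and that compound 3 gives > 200 mg/kg. Compound 4 is therefore estimated at 300 mg/kg, with a range from 150 mg/kg to 1000 mg/kg, and most likely the assay will again report only a limit.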

Compound 4, dose for half-maximal effect: > 200 mg/kg
Compound 4 ended at the assay's limit; the forecaster's own chance of this, stated with the estimate: 85%; the middle value lies beyond the limit too.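

The step from compound 3 to compound 4 cannot be read, as both compounds stay at a limit in this assay, which is true of the whole set: the limit of > 200 mg/kg in this assay, at which 4 of the 4 values shown sit.

The compounds shown leave open whether any of the four gives a number in this assay, and so how methylsulfonyl in place of methylsulfanyl acts on either core.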